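This account rests on a few compounds, and the source may have more. Where it says the series, first, only, none or still open, it means among the compounds named here.

Measured in a physicochemical assay for solubility; on this read-out higher numbers stand for higher solubility and lower numbers for lower solubility:
- Compound 1 `C[C@H](Oc1ccc(S(C)(=O)=O)cc1C(=O)N1Cc2cc(C(F)(F)F)cnc2C1)C(F)(F)F`: 280 ug/mL
- Compound 2 `CS(=O)(=O)c1ccc(OCCC(F)(F)F)c(C(=O)N2Cc3ccc(C4CCOCC4)cc3C2)c1`: 334 ug/mL

Going by the values given here, compound 1 stands within the scatter of compound 2, the only other compound measured, so neither can be ranked above the other. Among the compounds with values here, no measured step links two compounds that differ in one place, leaving the expectation without direct precedent. Compound 3 `CS(=O)(=O)c1ccc(-c2ccc(F)c(F)c2)c(C(=O)N2Cc3cc(C(F)(F)F)cnc3C2)c1` carries 3,4-difluorophenyl in place of 1-(trifluoromethyl)ethoxy on an aromatic carbon, para to a methylsulfonyl group (3,4-difluorophenyl in place of 1-(trifluoromethyl)ethoxy on an aromatic carbon). A moderate downward step beyond the scatter is expected, estimated as a 4.7-fold lower number from compound 1 to compound 3 (0.67 log units; beyond the scatter). The estimate for compound 3 is 60 ug/mL, with an expected range of 15 ug/mL to 220 ug/mL.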

Compound 3, solubility: 42 ug/mL
Estimate against measurement, compound 3: 1.4-fold (0.15 log units) above, and the stated range covers the measured number.
By their numbers in this assay, from the lowest: compound 3; then compounds 1 and 2 (each within the scatter of the next).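

In this assay, 3,4-difluorophenyl in place of 1-(trifluoromethyl)ethoxy gives a 6.7-fold lower number from compound 1 to compound 3 (0.82 log units; beyond the scatter) on the shared core, the first single-place comparison available. It shows that this aromatic carbon, para to a methylsulfonyl group, does not tolerate every exchange without a change in the read-out, something the earlier pair, which differs in more than one place, could not show. No measurement shown accounts for the step.

Open, going by these compounds, is whether a plain phenyl or a morpholine at this position would stand nearer compound 1 or compound 3. Also open, on these data alone, is whether the same exchange would give a step of similar size on another core.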